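Ketone chain variation in the acid-linked series

The source may hold more compounds than are shown below. What is called first, only, known or untested is meant among the compounds shown, and "the series" means these compounds.

Measured so far:
compound 1, `CCCC(=O)c1ccc(OCCCCOc2ccc(C(=O)O)cc2C)c(C)c1O`, in an assay on HEK293 cells for positive allosteric modulation of metabotropic glutamate receptor 3 (Rattus norvegicus), read by thallium flux, with a stated time of 2.5 min; a higher number here means that more compound is needed for the effect, a lower number that less compound is needed: > 10000 nM (a limit of the assay, not a number)
compound 2, `CCCC(=O)c1ccc(OCCCCOc2cc(C(=O)O)ccc2OC)c(C)c1O`, in this assay: 496 nM

Going by the values given here, compound 2 holds the only number so far in this assay; the other entry is the limit (the limit of > 10000 nM in this assay, at which 1 of the 2 values shown sits), so no step between measured compounds can be read. Compound 3, `COc1ccc(C(=O)O)cc1OCCCCOc1ccc(C(=O)C(C)C)c(O)c1C`, is the next candidate in this assay. It differs from compound 2 by isopropyl in place of propyl on a carbonyl carbon, the rest of the structure being unchanged. Among the compounds with values here, with no measured step of this kind to lean on, the expectation is that the change from compound 2 to compound 3 stays within the usual scatter, and the step of a 1.2-fold higher number from compound 2 to compound 3 (0.08 log units; within the scatter) is estimated to be small, if anything toward more compound needed. Compound 3 is therefore expected to give about 600 nM in this assay, with a plausible range from 200 nM to 2000 nM.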

Compound 3, half-maximal effective concentration: 588 nM
Estimate against measurement, compound 3: 1.0-fold (0.01 log units) above, within the range that was stated.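

The step in this assay, a 1.2-fold higher number from compound 2 to compound 3 (0.07 log units; within the scatter), gives the series its first readable comparison at this position, on a carbonyl carbon. Isopropyl in place of propyl, the same atoms joined differently, leaves the two compounds within the scatter of each other, so this position accepts the branched chain without a readable change in the number. No measured property in the data bears on a cause for this result.

Compound 1 remains a limit of the assay, and steps to it cannot be read: the limit of > 10000 nM in this assay, at which 1 of the 3 values shown sits. From the compounds shown here alone, a longer chain such as pentyl, a cyclopropyl ring or a phenyl group on the carbonyl carbon remains open, as does whether any replacement there moves the number beyond the scatter.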